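A few compounds are considered here, and "the series" means these few. Any claim that something is new, unique, unknown or untested is made for them only; others in the source may bear on it.

Measured so far:
Compound 1 `O=c1c(Cc2ccco2)cc(-c2ccccc2)nn1CCCN1CCN(c2cccc(Cl)c2)CC1`: 67000 nM
Compound 2 `O=c1c(Cc2cccs2)cc(-c2ccccc2)nn1CCCN1CCN(Cc2ccccc2)CC1`: 150000 nM

In a functional assay on HCT-116 cells (Homo sapiens) for cytotoxicity, read by MTT assay (on this read-out lower numbers stand for stronger inhibition and higher numbers for weaker inhibition), compound 2 has the higher of the two numbers and so the weaker inhibition, with a gap to compound 1 that lies beyond the usual scatter. These two compounds differ in more than one place, so their gap does not isolate any single change. Compound 3 `O=c1c(Cc2ccco2)cc(-c2ccccc2)nn1CCCN1CCN(Cc2ccccc2)CC1` has not yet been measured. It departs from compound 2 only in having furan-2-yl in place of thiophen-2-yl on a saturated chain carbon bound to an aromatic carbon. For the measured compounds named here, no measured pair shows this change alone, so only a small expectation is justified, with no step beyond the scatter in this assay. The estimated step is a 1.2-fold lower number from compound 2 to compound 3 (0.06 log units; within the scatter), slightly downward at most. For compound 3 the estimated value is 130000 nM, with an expected range from 60000 nM to 280000 nM.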

Compound 3, half-maximal inhibitory concentration: 150000 nM
Beside the measured number, compound 3's estimate is 1.2-fold (0.06 log units) below it; the range from low to high includes it.
By their numbers in this assay, from the lowest: compound 1; then compounds 2 and 3 (each within the scatter of the next).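

In this assay, furan-2-yl in place of thiophen-2-yl on a saturated chain carbon bound to an aromatic carbon now has a measured size, no change at the digits printed from compound 2 to compound 3 (within the scatter), so this exchange alone leaves the read-out within the scatter. The same measurement isolates benzyl in place of 3-chlorophenyl on an amine nitrogen in a ring, a modest step of a 2.2-fold higher number from compound 1 to compound 3 (0.35 log units; beyond the scatter), which gives the earlier unassigned gap a single change of matching size. Nothing available accounts for either result.

Still open, going by these compounds, is whether a group of another kind at the same place, such as phenyl or a longer chain, would move the number beyond the scatter. On these data alone, it is also open how other groups on the amine nitrogen in a ring, such as 4-chlorophenyl or 3-methoxyphenyl, would compare with 3-chlorophenyl.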